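Swapping the Catechol Ring for a Dinitrophenyl Ring

The compounds below may be only part of what the source reports. "The series", "measured", "known", "first", "only" and "open" are said of these compounds alone.

For the measured compounds named here, in an ADME assay on HEK-293T cells (Homo sapiens) for cytotoxicity, read by CCK-8 assay, with a stated time of 48 h (a lower number here means a stronger inhibitor, a higher number a weaker inhibitor), compound 2 `O=C(NCCNS(=O)(=O)c1ccc(-c2ccccc2Oc2ccc(O)c(O)c2)s1)Nc1cc(Cl)cc(Cl)c1` gives 12400 nM, the only exact number so far. Compound 1 `Cc1cc(C)cc(NC(=O)NCCNS(=O)(=O)c2ccc(-c3ccccc3Oc3ccc([N+](=O)[O-])c([N+](=O)[O-])c3)s2)c1`, which also carries 3,4-dinitrophenyl, gives > 50000 nM, a limit of the assay and not a number. Compound 3 `O=C(NCCNS(=O)(=O)c1ccc(-c2ccccc2Oc2ccc([N+](=O)[O-])c([N+](=O)[O-])c2)s1)Nc1cc(Cl)cc(Cl)c1` keeps the rest of compound 2 but places 3,4-dinitrophenyl in place of 3,4-dihydroxyphenyl on an oxygen on an aromatic ring. The reading of compound 1 points toward a modestly weaker value for compound 3, so the expected change is a 2.4-fold higher number from compound 2 to compound 3 (0.38 log units; beyond the scatter). For compound 3, the estimated value is 30000 nM, with an expected range from 13000 nM to 50000 nM.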

Compound 3, half-maximal inhibitory concentration: > 20000 nM
Compound 3 gave a limit, no number; the forecaster's own chance of this, stated with the estimate: 40%; the middle value is on the limit's open side.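

Compound 3 tests the change directly, with 3,4-dinitrophenyl in place of 3,4-dihydroxyphenyl and the rest of compound 2 kept. In this assay, this change gives an at least 1.6-fold higher number from compound 2 to compound 3 (0.20 log units; that floor lies within the scatter). Compound 3 has a limit of the assay and not a number, so the data show neither a clear shift nor its full size.

Compound 1 and compound 3 both have limits, and the step between them cannot be read. From the compounds shown here alone, how a phenyl ring carrying an amine or a carboxylic acid would read at this position also remains open.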